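The source may report more compounds than this note shows. Statements on the series, on what has been measured and on what is new or still open speak of the compounds shown alone.

Among the compounds with values here, compound 2 `CCCCCCCCCCCCCCCC(=O)N1CCCC1` gives 5.5 ug/mL in a functional assay on 786-0 cells (Homo sapiens) for antiproliferative activity, read by sulforhodamine B assay, with a stated time of 48 h (on this read-out lower numbers stand for stronger inhibition of growth and higher numbers for weaker inhibition of growth), the lowest of the three numbers measured so far. Compound 3 `CCCCCCCCCCCCCCCC(=O)N1CCOCC1` gives 33.1 ug/mL, and the step of a 6.0-fold higher number from compound 2 to compound 3 (0.78 log units; beyond the scatter) lies beyond the scatter. Compound 1 `CCCCCCCCCCCCCCCCCC(=O)N1CCOCC1` gives 41.1 ug/mL. The unmeasured compound 4 `CCCCCCCCCCCCCCCCCC(=O)N1CCCC1` differs from compound 2 only in the chain: ethyl in place of hydrogen on a saturated chain carbon, ten or more bonds along the chain from a carbonyl carbon. Within the data shown here, the one measured step that bears on this is the reverse change in the other pair, a 1.2-fold lower number from compound 1 to compound 3 (0.09 log units; within the scatter), which stays within the scatter. On that basis the step from compound 2 to compound 4 is expected to be small, a 1.2-fold higher number from compound 2 to compound 4 (0.07 log units; within the scatter), with no change beyond the scatter. Compound 4 is therefore estimated at 6.5 ug/mL in this assay, in a range from 3.5 ug/mL to 12 ug/mL.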

Compound 4, concentration for 50% growth inhibition: 14 ug/mL
The estimate for compound 4 lay 2.2-fold (0.33 log units) below the measured number, outside the stated range (above it).
By their numbers in this assay, from the lowest: compound 2; then compound 4; then compounds 3 and 1 (each within the scatter of the next).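

In this assay, ethyl in place of hydrogen on this far chain carbon can shift the number, as a 2.5-fold higher number from compound 2 to compound 4 (0.41 log units; beyond the scatter) shows, whereas the matching step with morpholin-4-yl stayed within the scatter. Even so, the two cores do not clearly differ in their response to this chain change: the same change on two cores in this assay, a 1.2-fold lower number (0.09 log units; within the scatter) from compound 1 to compound 3 and a 2.5-fold lower number (0.41 log units; beyond the scatter) from compound 4 to compound 2, 2.0-fold (0.31 log units) apart, within the scatter of two such steps Pyrrolidin-1-yl in place of morpholin-4-yl also gives a lower number on the longer chain, a 2.9-fold lower number from compound 1 to compound 4 (0.47 log units; beyond the scatter), in line with the shorter chain: the same change on two cores in this assay, a 6.0-fold higher number (0.78 log units; beyond the scatter) from compound 2 to compound 3 and a 2.9-fold higher number (0.47 log units; beyond the scatter) from compound 4 to compound 1, 2.0-fold (0.31 log units) apart, within the scatter of two such steps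

Going by these compounds, whether a piperidin-1-yl group on the carbonyl carbon would behave more like pyrrolidin-1-yl or morpholin-4-yl remains open. So does the effect of a still longer chain.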